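Chloro to dimethylamino on the shared core

A few compounds are considered here, and "the series" means these few. Any claim that something is new, unique, unknown or untested is made for them only; others in the source may bear on it.

Three cores carry the same (2-hydroxyethoxy)methyl group and are tested in a functional assay on L1210 cells (Mus musculus) for inhibition; on this read-out lower numbers stand for stronger inhibition and higher numbers for weaker inhibition. Compound 1 `Cc1cn(COCCO)c(=O)[nH]c1=O` sits at the limit of > 1000 ug/mL in this assay, at which 1 of the 3 values shown sits; compound 1 gives > 1000 ug/mL, which is a limit of the assay and not a number. Compound 2 `Cc1nc2c(O)nc(N)nc2n1COCCO` gives 323 ug/mL in this assay. Compound 3 `Nc1nc2c(nc(Cl)n2COCCO)c(=O)[nH]1` gives 350 ug/mL in this assay; the values of compound 2 and compound 3 lie within the usual scatter of each other, so neither is set apart. Compound 4 `CN(C)c1nc2c(=O)[nH]c(N)nc2n1COCCO` is not yet measured. It differs from compound 3 by dimethylamino in place of chloro on an aromatic carbon. Among the measured compounds shown here, no measured pair in this set differs in one place only, so no measured step guides the size of this change. The expectation rests on compound 3 with 350 ug/mL. Compound 4 is expected to remain a weak inhibitor, with a step of a 1.4-fold higher number from compound 3 to compound 4 (0.15 log units; within the scatter) that is expected to stay near or only slightly beyond the scatter, toward weaker inhibition. Compound 4 is estimated at 500 ug/mL, range 150 ug/mL to 1600 ug/mL, with a fair chance that only a limit is reported.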

Compound 4, concentration for 50% inhibition: > 500 ug/mL
Compound 4 was reported as a limit (the forecaster's own chance of this, stated with the estimate: 30%); the middle value sits exactly at the limit.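

In this assay, the change on this aromatic carbon now has its first single-place reading in the series: an at least 1.4-fold higher number from compound 3 to compound 4 (0.15 log units; that floor lies within the scatter). Compound 4 gives > 500 ug/mL, which is a limit of the assay and not a number. Dimethylamino in place of chloro on this carbon, next to the ring atom that bears the (2-hydroxyethoxy)methyl group, brings no sign of stronger inhibition, and whether the step reaches beyond the scatter cannot be read: the limit of > 500 ug/mL in this assay, at which 1 of the 4 values shown sits.

The compounds shown leave open how a primary amine or a carboxylic acid on this carbon would read in this assay. Also open, from the compounds shown here alone, is whether any group at this place can move the read-out beyond the scatter of compound 3, toward stronger inhibition.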